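The source may hold more compounds than are shown below. What is called first, only, known or untested is meant among the compounds shown, and "the series" means these compounds.

In a physicochemical assay for solubility (on this read-out higher numbers stand for higher solubility and lower numbers for lower solubility), compound 1 `CN(C)CC(=O)N1CCC(NS(=O)(=O)c2cc(S(=O)(=O)c3ccccc3)ccc2C(F)(F)F)CC1` gives 100000 nM and compound 2 `CC(C)(C)OC(=O)N1CCC[C@H]1C(=O)N1CCC(NS(=O)(=O)c2cc(S(=O)(=O)c3ccccc3)ccc2C(F)(F)F)CC1` gives 25000 nM as the lower of the two numbers. For the measured compounds named here, the only measured step, a 4.0-fold lower number from compound 1 to compound 2 (0.60 log units; beyond the scatter) on a carbonyl carbon, is modest but beyond the scatter. It offers only a rough guide to size for compound 3 `CC(C)C(=O)N1CCC[C@H]1C(=O)N1CCC(NS(=O)(=O)c2cc(S(=O)(=O)c3ccccc3)ccc2C(F)(F)F)CC1`. It is a different swap. Compound 3 differs from compound 2 by isopropyl in place of tert-butoxy on a carbonyl carbon on a carbonyl carbon. No step beyond the scatter is expected in this assay and the estimated change is a 1.4-fold higher number from compound 2 to compound 3 (0.15 log units; within the scatter) with a slight lean upward. Compound 3 is estimated at 35000 nM with an expected range from 13000 nM to 90000 nM around that middle.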

Compound 3, solubility: 100000 nM
Compound 3: middle estimate off by 2.9-fold (0.46 log units), on the low side; the measured number lies above the stated range.
By their numbers in this assay, from the lowest: compound 2; then compounds 1 and 3 (each within the scatter of the next).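

Swapping tert-butoxy for isopropyl on the carbonyl carbon gives, in this assay, a 4.0-fold higher number from compound 2 to compound 3 (0.60 log units; beyond the scatter), so this one change alone moves the read-out. Replacing (dimethylamino)methyl with 1-(isopropylcarbonyl)pyrrolidin-2-yl gives no change at the digits printed from compound 1 to compound 3 (within the scatter), so among these three compounds, the lower number appears only with tert-butoxy. No supporting measurement accounts for this shift. Still open, going by these compounds, is how other groups on this carbonyl carbon, such as a primary amine, a carboxylic acid or a longer alkyl chain, would compare with isopropyl and tert-butoxy.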